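Naphthalen-2-yl in Place of Phenyl on Compound 3

This account rests on a few compounds, and the source may have more. Where it says the series, first, only, none or still open, it means among the compounds named here.

Compound 3 `O=C1N=C(N2N=C(c3ccccc3)CC2c2ccc(Cl)cc2)S/C1=C1/C(=O)Nc2ccccc21` gives the lowest of three numbers in a functional assay on cells (Cancer cell lines, Homo sapiens) for cytotoxicity, read by sulforhodamine B assay, with a stated time of 48 h (a lower number here means a stronger inhibitor of growth, a higher number a weaker inhibitor of growth), at 250 nM. Compound 1 `O=C1N=C(N2N=C(c3ccccc3)CC2c2ccccc2O)S/C1=C1/C(=O)Nc2ccccc21` gives 2050 nM. Among the compounds with values here, the only single-change step seen, an 8.2-fold lower number from compound 1 to compound 3 (0.91 log units; beyond the scatter), concerns the group on the saturated ring carbon. Compound 4 `O=C1N=C(N2N=C(c3ccc4ccccc4c3)CC2c2ccc(Cl)cc2)S/C1=C1/C(=O)Nc2ccccc21` differs from compound 3 at another place: naphthalen-2-yl in place of phenyl on a carbon with a double bond to nitrogen. Within the data shown here, no measured step covers this change. Compound 2 `COc1ccc(C2CC(c3ccc4ccccc4c3)=NN2C2=NC(=O)/C(=C3\C(=O)Nc4ccccc43)S2)cc1` carries the same naphthalen-2-yl group together with a 4-methoxyphenyl group and gives 360 nM, which lies within the scatter of compound 3, so no step beyond the scatter is expected in this assay. Compound 4 is therefore estimated at 250 nM, with a range from 100 nM to 700 nM. This estimate amounts to an expected no change at the digits printed from compound 3 to compound 4 (within the scatter).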

Compound 4, concentration for 50% growth inhibition: 400 nM
Compound 4: the middle estimate sits 1.6-fold (0.20 log units) below what was measured, within the range that was stated.
By their numbers in this assay, from the lowest: compounds 3, 2 and 4 (each within the scatter of the next); then compound 1.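

In this assay, replacing phenyl with naphthalen-2-yl on the carbon with a double bond to nitrogen gives a 1.6-fold higher number from compound 3 to compound 4 (0.20 log units; within the scatter), so this position accepts the second aromatic ring without a change beyond the scatter. With naphthalen-2-yl in place, chloro instead of methoxy on the aromatic ring gives a 1.1-fold higher number from compound 2 to compound 4 (0.05 log units; within the scatter), so these two compounds cannot be told apart here. No measurement at hand speaks to the reason for these results. Still open, going by these compounds, is whether an amine, a carboxylic acid or a longer chain at this carbon would give a similar number. Also open, on these data alone, is how naphthalen-2-yl behaves alongside the 2-hydroxyphenyl group of compound 1.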